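The source may report more compounds than this note shows. Statements on the series, on what has been measured and on what is new or still open speak of the compounds shown alone.

Compound 1, `Cc1ccc(NC2=CC(=O)c3nc4n(c3C2=O)[C@H]2OC[C@@H](O)[C@H]2OC4)cc1`, gives 1660 nM in a functional assay on MCF7 cells (Homo sapiens) for inhibition, read by sulforhodamine B assay; a higher number here means a weaker inhibitor, a lower number a stronger inhibitor.
Compound 2, `COc1cccc(NC2=CC(=O)c3nc4n(c3C2=O)[C@H]2OC[C@@H](O)[C@H]2OC4)c1`, gives only a limit of the assay, > 4000 nM, in this assay.
Compound 3, `O=C1C=C(Nc2ccccc2)C(=O)c2c1nc1n2[C@H]2OC[C@@H](O)[C@H]2OC1`, likewise gives only a limit of the assay, > 4000 nM, in this assay.

Compound 3 therefore stands at the limit of > 4000 nM in this assay, at which 2 of the 3 values shown sit, so its true number is not known, only that it is weaker than that boundary. Compound 4, `O=C1C=C(Nc2ccc(C(F)(F)F)cc2)C(=O)c2c1nc1n2[C@H]2OC[C@@H](O)[C@H]2OC1`, has not yet been measured. It differs from compound 3 in one place: trifluoromethyl in place of hydrogen on an aromatic carbon.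

Among the compounds with values here, one measured step bears on this change. The step of an at least 2.4-fold higher number from compound 1 to compound 3 (0.38 log units; beyond the scatter) shows that removing a methyl from the same aromatic carbon gave a weaker inhibitor; read in reverse, putting a group onto that carbon gave a stronger one. The step that the two limits leave unreadable from compound 2 to compound 3 involves a different position and its size cannot be read from two limits. A trifluoromethyl entering at the same carbon that carried the methyl in compound 1 is therefore expected to move the number in this assay downward, by about an at least 1.8-fold lower number from compound 3 to compound 4 (0.25 log units; that floor lies within the scatter), though the starting point is itself only a limit, so the size is uncertain. Compound 4 is expected to give about 2200 nM, within a range from 800 nM to 6000 nM.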

Compound 4, half-maximal inhibitory concentration: > 4000 nM
Compound 4 ended at the assay's limit (the forecaster's own chance of this, stated with the estimate: 35%); middle value at least 1.8-fold (0.25 log units) away from the limit.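

In this assay, trifluoromethyl in place of methyl on this aromatic carbon gives an at least 2.4-fold higher number from compound 1 to compound 4 (0.38 log units; beyond the scatter), so filling this position does not by itself give a stronger inhibitor. What counts here is which group enters, and among the compounds shown, only the methyl of compound 1 gives a measured number rather than a limit. The steps from compound 2 and from compound 3 to compound 4 cannot be read, and compound 4 joins the same boundary: the limit of > 4000 nM in this assay, at which 3 of the 4 values shown sit.

From the compounds shown here alone, how far compound 3 and compound 4 truly lie apart stays open, as both values are only limits. Also open, going by these compounds, is whether an ethyl group, a chlorine atom or an amine on this carbon would give a measured number like that of compound 1 or a limit like that of compound 4.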